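The compounds below may be only part of what the source reports. "The series", "measured", "known", "first", "only" and "open" are said of these compounds alone.

Working notes on the series, read in a functional assay on VCaP cells (Homo sapiens) for antiproliferative activity, read by propidium iodide staining, with a stated time of 96 h; a higher number here means a weaker inhibitor, a lower number a stronger inhibitor. Here compound 1 `CC(O)(COc1cccc(S(F)(F)(F)(F)F)c1)C(=O)Nc1ccc(C#N)c(C(F)(F)F)c1` gives 8000 nM, compound 2 `CC(O)(COc1ccc(C#N)cc1C(F)(F)F)C(=O)Nc1cccc(S(F)(F)(F)(F)F)c1` gives 30600 nM, and compound 3 `CC(O)(CS(=O)(=O)c1ccc(S(F)(F)(F)(F)F)cc1)C(=O)Nc1ccc(S(F)(F)(F)(F)F)cc1` gives 15700 nM. Compound 3 lies within the scatter of both compound 1 and compound 2, so it cannot be ranked against either of them on these numbers.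

The next compound to read is compound 4 `CC(O)(CS(=O)(=O)c1ccc(OC(F)(F)F)cc1)C(=O)Nc1ccc(S(F)(F)(F)(F)F)cc1`, which keeps the rest of compound 3 and changes one group: a group of 5 heavy atoms (1 carbon, 1 oxygen, 3 fluorine; no ring) in place of a group of 6 heavy atoms (5 fluorine, 1 sulfur; no ring), on an aromatic carbon. Trifluoromethoxy enters on an aromatic carbon of a six-membered aromatic ring of carbon only, para to a large group. Among the measured compounds shown here, no pair of measured compounds differs in one place only, so no measured step calibrates this change.

In this assay no step beyond the scatter is expected, in either direction. This expectation rests only on how close compound 3 at 15700 nM stands to the other two measured compounds. The estimated step of a 1.0-fold lower number from compound 3 to compound 4 (0.02 log units; within the scatter) is therefore small. For compound 4 the estimated value is 15000 nM, with an expected range from 6000 nM to 38000 nM.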

Compound 4, half-maximal inhibitory concentration: 95800 nM
The estimate for compound 4 lay 6.4-fold (0.81 log units) below the measured number; the measured number lies above the stated range.
By their numbers in this assay, from the lowest: compounds 1, 3 and 2 (each within the scatter of the next, the first and the last beyond it); then compound 4.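

In this assay, among the compounds shown here, a 6.1-fold higher number from compound 3 to compound 4 (0.79 log units; beyond the scatter) is the first step that can be read in one place, and it lies beyond the scatter. It shows that this position, on an aromatic carbon para to a large group, responds to a single change, and that trifluoromethoxy does not stand in for the group of 6 heavy atoms (5 fluorine, 1 sulfur) without a loss of activity, even though the two groups differ little in heavy-atom count. No measurement on these compounds accounts for the step, so it stands as an observation only.

With a single replacement shown at this position, it remains open whether the loss belongs to trifluoromethoxy itself or would follow any departure from the group it replaced, and a chlorine atom or a methyl group on the same aromatic carbon would help to separate the two readings. Also open, from the compounds shown here alone, is whether the step carries over to other parts of the series, since compound 1 and compound 2 each differ from compound 3 and compound 4 in more than one place.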